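The compounds below may be only part of what the source reports. "The series", "measured", "known", "first", "only" and "open" are said of these compounds alone.

The three measured compounds share one core and differ only in the group on the ring nitrogen. In an assay on CHO cells for displacement of a labelled ligand from adenosine receptor A3 (Homo sapiens), read by scintillation counting, with a stated time of 120 min, tested at 10 uM (a lower number here means less inhibition, a higher number more inhibition at the concentration tested (going by the name of the read-out)), compound 1 `CC(C)N1CCN(Cc2csc(N)c2C(=O)c2ccc(Cl)cc2)CC1` gives 0%. Compound 2 `Nc1scc(CN2CCN(c3ccc([N+](=O)[O-])cc3)CC2)c1C(=O)c1ccc(Cl)cc1` gives 2% in this assay, and compound 3 `Nc1scc(CN2CCN(c3ccccc3Cl)CC2)c1C(=O)c1ccc(Cl)cc1` gives 0% in this assay. Compound 3 thus stands level with compound 1, the two together at the lowest of the three numbers; the step of no change at the digits printed from compound 1 to compound 3 (within the scatter) and the step of a number 2 percentage points lower from compound 2 to compound 3 (within the scatter) both lie within the scatter, as does a number 2 percentage points higher from compound 1 to compound 2 (within the scatter). None of the exchanges at this position has moved the read-out beyond the scatter. Compound 4 `Nc1scc(CN2CCN(c3ccc(Cl)c(Cl)c3)CC2)c1C(=O)c1ccc(Cl)cc1` differs from compound 3 by 3,4-dichlorophenyl in place of 2-chlorophenyl on an amine nitrogen in a ring. Because no change at the digits printed from compound 1 to compound 3 (within the scatter) and a number 2 percentage points lower from compound 2 to compound 3 (within the scatter) stayed within the scatter for two other exchanges at the same ring nitrogen, compound 4 is expected to show no change at the digits printed from compound 3 to compound 4 (within the scatter) in this assay, no step beyond the scatter. Compound 4 is therefore estimated at 0%, with a range from 0% to 10%.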

Compound 4, a percentage reported as inhibition, at one concentration (the size of the read-out at that concentration, not a potency): 3%
Estimate against measurement, compound 4: 3 percentage points below; measured number inside the range.
By their numbers in this assay, from the lowest: compounds 1, 3, 2 and 4 (each within the scatter of the next).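

With 3,4-dichlorophenyl, a phenyl group carrying two chlorines now sits on the ring nitrogen, and in this assay the picture stays flat: the steps of a number 3 percentage points higher from compound 3 to compound 4 (within the scatter) and a number 1 percentage points higher from compound 2 to compound 4 (within the scatter) and a number 3 percentage points higher from compound 1 to compound 4 (within the scatter) all leave this exchange without effect beyond the scatter. The second chlorine thus separates compound 4 from none of the other three compounds, whether the group it replaces is 2-chlorophenyl, 4-nitrophenyl or isopropyl. Nothing further is available that would explain these numbers.

From the compounds shown here alone, whether a different kind of group on this ring nitrogen, such as a carboxylic acid or a longer alkyl chain, would lift the read-out stays open. Also open, going by these compounds, is whether a change elsewhere on the shared core, such as an amide in place of the free amine, would do so.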